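This account rests on a few compounds, and the source may have more. Where it says the series, first, only, none or still open, it means among the compounds named here.

Measured in a functional assay on U-251 cells (Homo sapiens) for antiproliferative activity; a higher number here means a weaker inhibitor of growth, a lower number a stronger inhibitor of growth:
Compound 1 `Cc1ccc2c(O)cc(-c3cccc(Cl)c3)nc2n1`: 64.6 nM
Compound 2 `Cc1cccc(-c2cc(O)c3ccc(C)nc3n2)c1`: 200 nM
Compound 3 `Oc1cc(-c2ccc3ccccc3c2)nc2ncccc12`: 4370 nM

Compound 2 (200 nM) holds the second highest of the three numbers in this assay, with compound 1 lower and compound 3 higher. Compound 4 `Cc1cccc(-c2cc(O)c3c(C)cc(C)nc3n2)c1` carries methyl in place of hydrogen on an aromatic carbon, opposite the ring nitrogen methyl in place of hydrogen on an aromatic carbon of compound 2. Going by the values given here, no measured step adds a methyl at this place. The nearest guide is the modest step of a 3.1-fold higher number from compound 1 to compound 2 (0.49 log units; beyond the scatter) (methyl in place of chloro, elsewhere in the structure), which suggests size but not direction. A similarly modest rise in the number is therefore expected, though a change within the scatter remains possible. The estimated change is a 1.8-fold higher number from compound 2 to compound 4 (0.24 log units; within the scatter) (an expectation only). For compound 4 the expected value is 350 nM (estimated range 90 nM to 1500 nM).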

Compound 4, concentration for 50% growth inhibition: 53700 nM
Estimate against measurement, compound 4: 150-fold (2.19 log units) below, and the stated range ends below it.
By their numbers in this assay, from the lowest: compound 1; then compound 2; then compound 3; then compound 4.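

In this assay, methyl in place of hydrogen on an aromatic carbon, opposite the ring nitrogen, gives a 270-fold higher number from compound 2 to compound 4 (2.43 log units; beyond the scatter). Going by these compounds alone, this is a much larger change than the one at the other methyl, a 3.1-fold higher number from compound 1 to compound 2 (0.49 log units; beyond the scatter), so this position is far more sensitive to a single added carbon than the earlier compounds could show. Nothing given here explains the rise. As far as these compounds go, whether any group at this place has the same effect stays open, since fluoro, methoxy or an amine there would test it. Also open, from the compounds shown here alone, is whether the same methyl would cost as much on compound 1.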